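A few compounds are considered here, and "the series" means these few. Any claim that something is new, unique, unknown or untested is made for them only; others in the source may bear on it.

Compound 1 `CCC(=O)Nc1ccc(S(=O)(=O)Oc2ccccc2I)cc1` and compound 2 `O=C(CCCl)Nc1ccc(S(=O)(=O)Oc2ccccc2I)cc1` share one core and differ only in the chain of the amide. In a functional assay on MCF7 cells (Homo sapiens) for antiproliferative activity, read by sulforhodamine B assay, with a stated time of 48 h (a lower number here means a stronger inhibitor, a higher number a weaker inhibitor), compound 1 gives 8100 nM, and compound 2 gives 8900 nM. The step of a 1.1-fold higher number from compound 1 to compound 2 (0.04 log units; within the scatter) shows that the chloro in place of hydrogen on the saturated chain carbon left the number essentially unchanged. Of the two numbers, compound 2 holds the higher one, but its gap to compound 1 lies within the scatter, so the two cannot be ranked. Compound 3 `CCNC(=O)Nc1ccc(S(=O)(=O)Oc2ccccc2I)cc1` arises from compound 2 by the change (ethylamino in place of 2-chloroethyl on a carbonyl carbon); cut one bond further out, the same difference reads ((2-chloroethyl)carbonyl)amino to (ethylcarbamoyl)amino. Going by the values given here, no measured step covers such an exchange; the only step at hand, a 1.1-fold higher number from compound 1 to compound 2 (0.04 log units; within the scatter), touched the chain end and was within the scatter, so no direction can be drawn from it. For compound 3 the value expected in this assay is therefore 9000 nM, within 3000 nM to 30000 nM. The expected step of a 1.0-fold higher number from compound 2 to compound 3 (0.00 log units; within the scatter) is not beyond the scatter.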

Compound 3, half-maximal inhibitory concentration: 1100 nM
Estimate against measurement, compound 3: 8.2-fold (0.91 log units) above, and the stated range ends above it.
By their numbers in this assay, from the lowest: compound 3; then compounds 1 and 2 (each within the scatter of the next).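

In this assay, ethylamino in place of 2-chloroethyl on the carbonyl carbon gives an 8.1-fold lower number from compound 2 to compound 3 (0.91 log units; beyond the scatter) and ethylamino in place of ethyl gives a 7.4-fold lower number from compound 1 to compound 3 (0.87 log units; beyond the scatter), so this position can move the number beyond the scatter, which the chloro exchange on the chain end did not do. Compounds 1 and 2 lie within the scatter of each other, so these two steps amount to one observation: the lower number comes with ethylamino on the carbonyl carbon in both comparisons. No measurement shown here explains why this exchange lowers the number.

From the compounds shown here alone, it remains open whether ethylamino is special or whether other groups on the carbonyl carbon, such as a plain amino group, methylamino, propylamino or ethoxy, would give a similar number. The shown compounds also leave open whether a ring on that nitrogen, such as phenyl, would be tolerated.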